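Compound 3 to compound 4: swapping the anilide group

The source may hold more compounds than are shown below. What is called first, only, known or untested is meant among the compounds shown, and "the series" means these compounds.

In a functional assay on HepG2 cells (Homo sapiens) for inhibition, read by MTT assay, with a stated time of 72 h (a lower number here means a stronger inhibitor, a higher number a weaker inhibitor), compound 3 (`O=C(Nc1ccc(F)c(Br)c1)C1CCN(C/C=C/c2ccccc2)CC1`) gives 8190 nM and stands within the scatter of compound 1 (`CCCc1ccc(NC(=O)C2CCN(C/C=C/c3ccccc3)CC2)cc1`) at 9410 nM and of compound 2 (`CC(C)c1ccc(NC(=O)C2CCN(C/C=C/c3ccccc3)CC2)cc1`) at 12200 nM in the same test. Compound 4 (`N#Cc1ccc(NC(=O)C2CCN(C/C=C/c3ccccc3)CC2)cc1`) carries 4-cyanophenyl in place of 3-bromo-4-fluorophenyl on an amide-type nitrogen. Two measured steps replace the group at that place (a 1.1-fold lower number from compound 1 to compound 3 (0.06 log units; within the scatter)) and (a 1.5-fold lower number from compound 2 to compound 3 (0.17 log units; within the scatter)), and the step within the alkyl pair (a 1.3-fold higher number from compound 1 to compound 2 (0.11 log units; within the scatter)) is equally small. No nitrile has been measured yet, so no step beyond the scatter is expected in this assay and no direction is favoured. The estimated step is small (a 1.2-fold higher number from compound 3 to compound 4 (0.06 log units; within the scatter)) and lies within the scatter. Compound 4 is expected at 9500 nM with an estimated range from 4500 nM to 20000 nM in this series.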

Compound 4, half-maximal inhibitory concentration: 38300 nM
Estimate against measurement, compound 4: 4.0-fold (0.61 log units) below, outside the stated range (above it).
By their numbers in this assay, from the lowest: compounds 3, 1 and 2 (each within the scatter of the next); then compound 4.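

In this assay, among the compounds shown here, this place on the amide-type nitrogen proves sensitive to the group it carries: 4-cyanophenyl gives a 4.7-fold higher number from compound 3 to compound 4 (0.67 log units; beyond the scatter) and a 3.1-fold higher number from compound 2 to compound 4 (0.50 log units; beyond the scatter) and a 4.1-fold higher number from compound 1 to compound 4 (0.61 log units; beyond the scatter) as the steps away from the earlier compounds. For the compounds shown here, those earlier compounds, with propyl, isopropyl or 3-bromo-4-fluorophenyl, stay within the scatter of one another, so the nitrile is the first group here to move the number. No measurement shown explains this rise.

Open, from the compounds shown here alone, is whether the rise is peculiar to the nitrile or also appears with a carboxylic acid or an amine in its place. A 3-cyanophenyl group on the same nitrogen would show whether it depends on where the nitrile sits on the ring.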